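Swapping Chloro for Isopropoxy: Expected Cytotoxicity of Compound 4

The source may hold more compounds than are shown below. What is called first, only, known or untested is meant among the compounds shown, and "the series" means these compounds.

Compound 1 `COc1ccc(C2=C(c3cc(OC)c(OC)c(OC)c3)CC(O[SiH2]C(C)(C)C)C2=O)cc1[N+](=O)[O-]` gives > 100 ug/mL in an ADME assay on L132 cells (Homo sapiens) for cytotoxicity, read by MTT assay, with a stated time of 72 h; a lower number here means a stronger inhibitor, a higher number a weaker inhibitor; this is a limit of the assay, not a number.
Compound 2 `COc1ccc(C2=C(c3cc(OC)c(OC)c(OC)c3)C(=O)C(OC(C)=O)C2)cc1Cl` gives < 1 ug/mL in this assay; this too is a limit.
Compound 3 `COc1ccc(C2=C(c3cc(OC)c(OC)c(OC)c3)CC(O)C2=O)cc1[N+](=O)[O-]` gives > 100 ug/mL in this assay; again a limit.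

Compound 2 thus stands alone at the limit of < 1 ug/mL in this assay, at which 1 of the 3 values shown sits. Compound 1 and compound 3 both sit at the limit of > 100 ug/mL in this assay, at which 2 of the 3 values shown sit. Compound 4 `COc1ccc(C2=C(c3cc(OC)c(OC)c(OC)c3)C(=O)C(OC(C)=O)C2)cc1OC(C)C` differs from compound 2 by isopropoxy in place of chloro on an aromatic carbon. Within the data shown here, the only measured step, a step that the two limits leave unreadable from compound 1 to compound 3, alters a different part of the shared core and its size cannot be read, so no measured step bears on the change from compound 2 to compound 4. With compound 2 itself at a limit, neither the size nor the direction of the coming step can be taken from these data. Compound 4 is expected to give 3 ug/mL, with a range from 0.5 ug/mL to 20 ug/mL. This estimate corresponds to an expected step of an at least 3.0-fold higher number from compound 2 to compound 4 (0.47 log units; beyond the scatter).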

Compound 4, half-maximal inhibitory concentration: > 100 ug/mL
Compound 4: a limit, no number; the forecaster's own chance of this, stated with the estimate: 30%; middle value at least 33-fold (1.52 log units) away from the limit.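

On the aromatic carbon ortho to a methoxy group, isopropoxy in place of chloro gives an at least 100-fold higher number from compound 2 to compound 4 (2.00 log units; beyond the scatter) in this assay. This is the first readable step among the compounds shown, and it shows that a change at this one place can carry the shared core from one end of the measured range to the other. Compound 4 gives a limit of the assay, not a number, and it joins the weak end: the limit of > 100 ug/mL in this assay, at which 3 of the 4 values shown sit.

On these data alone, whether ethoxy or an amine on this aromatic carbon would give a real number between the two limits stays open. As far as these compounds go, the true size of the step also stays open, since both of its ends are limits.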